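The source may report more compounds than this note shows. Statements on the series, on what has been measured and on what is new or still open speak of the compounds shown alone.

Compound 1 `C=CCOc1ccc(C(=O)Nc2cccc(C)n2)cc1` is the reference point of the set. In an in vitro assay on HEK-tsA201 cells for antagonist activity at Neuronal acetylcholine receptor; alpha3/beta4 (Homo sapiens), read by fluorescence and calcium flux (a higher number here means a weaker inhibitor, a lower number a stronger inhibitor), compound 1 gives 31700 nM, the highest of the three numbers measured, though both other compounds lie within the scatter of it: compound 2 `C#CCOc1ccc(C(=O)Nc2cccc(C)n2)cc1` gives 21700 nM, and compound 3 `CCOc1ccc(C(=O)Nc2cc(C)cc(C)n2)cc1` gives 17400 nM. Going by the values given here, the only step between two compounds differing in one place, a 1.5-fold lower number from compound 1 to compound 2 (0.16 log units; within the scatter), stays within the scatter. Compound 4 `C=CCOc1ccc(C(=O)Nc2cccc(CC)n2)cc1` differs from compound 1 by methyl in place of hydrogen on a saturated chain carbon bound to an aromatic carbon. Among the compounds with values here, no measured pair tests that change; compound 3 differs from compound 1 in more than one place, so its value bears only loosely here. The expectation is therefore no step beyond the scatter, a 1.1-fold lower number from compound 1 to compound 4 (0.05 log units; within the scatter). Compound 4 is estimated in this assay at 28000 nM, between 10000 nM and 80000 nM.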

Compound 4, half-maximal inhibitory concentration: 27400 nM
The estimate for compound 4 lay 1.0-fold (0.01 log units) above the measured number, and the stated range covers the measured number.
By their numbers in this assay, from the lowest: compounds 3, 2, 4 and 1 (each within the scatter of the next).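

In this assay, the first single change tested at this place, methyl to ethyl on a saturated chain carbon bound to an aromatic carbon, gives a 1.2-fold lower number from compound 1 to compound 4 (0.06 log units; within the scatter). This place therefore takes the added methyl with no readable shift, whereas the earlier one-place step concerned a different place, a saturated chain carbon bound to an oxygen on an aromatic ring. No supporting evidence bears on this result. From the compounds shown here alone, whether a longer chain such as propyl, an amine or a carboxylic acid here would give a step beyond the scatter remains open.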